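Trimethoxyphenyl in Place of Chlorophenyl on a Weak Series

The compounds below may be only part of what the source reports. "The series", "measured", "known", "first", "only" and "open" are said of these compounds alone.

Compound 1 `O=C(/C=C\Nc1ccc(Cl)cc1)c1cn(-c2ccccc2)nc1-c1ccc(Cl)cc1`: in an ADME assay on HaCaT cells (Homo sapiens) for antiproliferative activity, read by MTT assay, with a stated time of 48 h (on this read-out lower numbers stand for stronger inhibition and higher numbers for weaker inhibition), compound 1 gives 23400 nM.
Compound 2 `O=C(/C=C\Nc1ccc(C(F)(F)F)cc1)c1cn(-c2ccccc2)nc1-c1ccc(Cl)cc1`: in this assay compound 2 gives only a limit, > 50000 nM.

The two measured compounds share one core and differ in a single place: trifluoromethyl in place of chloro on an aromatic carbon gives an at least 2.1-fold higher number from compound 1 to compound 2 (0.32 log units; beyond the scatter). Compound 2 therefore stands at the weaker end of the two numbers shown, and its value is a limit of this assay rather than a number, as the limit of > 50000 nM in this assay, at which 1 of the 2 values shown sits, records.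

Compound 3 `COc1cc(-c2nn(-c3ccccc3)cc2C(=O)/C=C\Nc2ccc(C(F)(F)F)cc2)cc(OC)c1OC` differs from compound 2 by 3,4,5-trimethoxyphenyl in place of 4-chlorophenyl on an aromatic carbon. For the measured compounds named here, no measured step touches this group: the only step on record, an at least 2.1-fold higher number from compound 1 to compound 2 (0.32 log units; beyond the scatter), exchanges a different group at a different place, so the data give no size and no direction for the change from compound 2 to compound 3 in this assay.

With compound 2 already reporting only a limit, compound 3 is expected to return a similar read-out, an estimated 50000 nM with a range from 15000 nM to 150000 nM, corresponding to an expected a number no higher from compound 2 to compound 3 (the limit leaves the size open).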

Compound 3, half-maximal inhibitory concentration: > 50000 nM
Compound 3 ended at the assay's limit; the forecaster's own chance of this, stated with the estimate: 60%; the middle value sits exactly at the limit.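

In this assay compound 3 gives > 50000 nM, a limit and not a number. Compound 2 gives > 50000 nM, also a limit. No step between compound 2 and compound 3 can be read, as both stand at the same mark: the limit of > 50000 nM in this assay, at which 2 of the 3 values shown sit.

From the compounds shown here alone, what 3,4,5-trimethoxyphenyl in place of 4-chlorophenyl does to the read-out, in size or direction, stays open.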